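The compounds below may be only part of what the source reports. "The series", "measured", "known", "first", "only" and "open" are said of these compounds alone.

In a functional assay on U-251 cells (Homo sapiens) for inhibition, read by MTT assay, with a stated time of 2 days (a lower number here means a stronger inhibitor of growth, a higher number a weaker inhibitor of growth), the measured compounds stand as follows:
compound 1 `Nc1ccccc1NC(=O)CCCNCC(=O)Nc1ccc(Br)cc1` gives 10400 nM
compound 2 `Nc1ccccc1NC(=O)CCCNCC(=O)Nc1cccc([N+](=O)[O-])c1` gives 15000 nM
compound 3 `Nc1ccccc1NC(=O)CCCNCC(=O)Nc1ccccc1Cl` gives 28600 nM

Compound 3 cannot be separated from one neighbour, with a 1.9-fold higher number from compound 2 to compound 3 (0.28 log units; within the scatter), but it parts from the other, with a 2.8-fold higher number from compound 1 to compound 3 (0.44 log units; beyond the scatter). The next compound is compound 4 `COc1ccc(NC(=O)CNCCCC(=O)Nc2ccccc2N)cc1`, and the change is 4-methoxyphenyl in place of 2-chlorophenyl on an amide-type nitrogen.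

All three measured steps change the group at this same place. The remaining one is a 1.4-fold higher number from compound 1 to compound 2 (0.16 log units; within the scatter). Going by the values given here, the largest of them is modest, and no measured compound carries 4-methoxyphenyl, so the group itself has no direct precedent here. Among the compounds with values here, a small move toward lower numbers is expected, since the numbers of compound 1 and compound 2 both lie under that of compound 3, but no step clearly beyond the scatter is expected in this assay. The expected step is a 1.7-fold lower number from compound 3 to compound 4 (0.23 log units; within the scatter). For compound 4 the estimate is 17000 nM, with an expected range from 8000 nM to 32000 nM.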

Compound 4, concentration for 50% growth inhibition: 34000 nM
For compound 4 the middle estimate is 2.0-fold (0.30 log units) below the measured one; measured number above the stated range.
By their numbers in this assay, from the lowest: compounds 1, 2, 3 and 4 (each within the scatter of the next, the first and the last beyond it).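

In this assay, 4-methoxyphenyl cannot be separated from 2-chlorophenyl on the amide-type nitrogen, with a 1.2-fold higher number from compound 3 to compound 4 (0.08 log units; within the scatter), but it does part from 3-nitrophenyl, with a 2.3-fold higher number from compound 2 to compound 4 (0.36 log units; beyond the scatter). Methoxy in place of bromo on an aromatic carbon gives the widest step in the set, with a 3.3-fold higher number from compound 1 to compound 4 (0.51 log units; beyond the scatter), so a change of this one group on the phenyl ring is enough to move the number, though the step remains modest. No available data bear on the reason for these differences.

All of these compounds carry a substituted phenyl on this nitrogen, so the effect of an unsubstituted phenyl, a pyridyl ring or a saturated cyclohexyl group there remains open. It also remains open whether a longer chain in the shared core would shift the numbers or change the order seen among these groups.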